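A few compounds are considered here, and "the series" means these few. Any claim that something is new, unique, unknown or untested is made for them only; others in the source may bear on it.

Of the compounds shown here, three have so far been measured in an assay on isolated protein for agonist activity at Bile acid receptor (Homo sapiens), read by FRET; on this read-out higher numbers stand for an effect only at larger amounts of compound and lower numbers for an effect already at smaller amounts. Compound 1 `Cc1nc(OCc2c(-c3c(Cl)cccc3Cl)noc2C(C)C)ccc1N(C)C(=O)c1ccc(C(=O)O)cc1` gives 365 nM. Compound 2 `Cc1cc(OCc2c(-c3c(Cl)cccc3Cl)noc2C(C)C)nc2ccccc12` gives 147 nM. Compound 3 `CC(C)c1onc(-c2c(Cl)cccc2Cl)c1COc1ccc(N(C)Cc2ccc(CCC(=O)O)cc2)c(C(F)(F)F)n1` gives 17 nM, the lowest of the three numbers. Its gap to compound 2 and its larger gap to compound 1 both lie beyond the scatter, so compound 3 is the most potent of the measured set.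

Compound 4 `CC(C)c1onc(-c2c(Cl)cccc2Cl)c1COc1ccc(N(C)Cc2ccc(OCC(=O)O)cc2)c(C(F)(F)F)n1` has not yet been measured. It differs from compound 3 in a single place: carboxymethoxy in place of 2-carboxyethyl on an aromatic carbon. Among the measured compounds shown here, no measured pair shows this change, so its size can only be guessed. Because compound 3 already stands at 17 nM, the expected outcome for compound 4 is a number in the same region, with a step no larger than the scatter or a slight loss. The expected step is a 1.5-fold higher number from compound 3 to compound 4 (0.17 log units; within the scatter). For compound 4 the estimate in this assay is 25 nM, with a range from 8 nM to 80 nM.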

Compound 4, half-maximal effective concentration: 35 nM
Beside the measured number, compound 4's estimate is 1.4-fold (0.15 log units) below it; the range from low to high includes it.
By their numbers in this assay, from the lowest: compound 3; then compound 4; then compound 2; then compound 1.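

In this assay, among the compounds shown here, carboxymethoxy in place of 2-carboxyethyl on this aromatic carbon gives a 2.1-fold higher number from compound 3 to compound 4 (0.31 log units; beyond the scatter), the first step in the set that can be read at a single place. The two groups hold the same count of heavy atoms, with an oxygen in the entering group in place of a carbon and one more hydrogen-bond acceptor, so this position responds, though modestly, to an exchange within the chain that leaves its length in heavy atoms unchanged. Nothing measured here gives a reason for this step.

The compounds shown leave open how a longer chain such as 3-carboxypropyl, a tetrazole or a primary amine would fare at this position. They also leave open whether the same exchange would give a step of like size on another core.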